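Series notes: terminal amine change, compound 3 to compound 4

This account rests on a few compounds, and the source may have more. Where it says the series, first, only, none or still open, it means among the compounds named here.

Measured so far:
- Compound 1 `c1cncc(CN(CCCCN(C[C@H]2Cc3ccccc3CN2)[C@H]2CCCc3cccnc32)Cc2cccnc2)c1`: in a functional assay on cells for agonist activity at C-X-C chemokine receptor type 4 (Homo sapiens), read by fluorescence and calcium flux, with a stated time of 90 s (on this read-out lower numbers stand for an effect already at smaller amounts and higher numbers for an effect only at larger amounts of compound), compound 1 gives > 30000 nM, a limit of the assay.
- Compound 2 `c1cncc(CNCCCCN(C[C@H]2Cc3ccccc3CN2)[C@H]2CCCc3cccnc32)c1`: compound 2 gives > 30000 nM, a limit.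
- Compound 3 `c1ccc2c(c1)CN[C@@H](CN(CCCCNCC1CCOCC1)[C@H]1CCCc3cccnc31)C2`: compound 3 gives > 30000 nM, a limit.

Compound 3 therefore stands at the limit only, as do the other two values (the limit of > 30000 nM in this assay, at which 3 of the 3 values shown sit). Both measured steps, a step that the two limits leave unreadable from compound 1 to compound 2 and a step that the two limits leave unreadable from compound 2 to compound 3, are left unreadable by the limits and give no size or direction to carry forward. Compound 4 `c1ccc2c(c1)CN[C@@H](CN(CCCCNC1CCSCC1)[C@H]1CCCc3cccnc31)C2` differs from compound 3 by thian-4-yl in place of (oxan-4-yl)methyl on an amine nitrogen. For the measured compounds named here, no measured step reads on this change, so the step is expected to remain unreadable, a number no higher from compound 3 to compound 4 (the limit leaves the size open). Compound 4 is estimated at 30000 nM, in a range from 10000 nM to 100000 nM, most likely reported again as a limit.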

Compound 4, half-maximal effective concentration: > 30000 nM
Compound 4 was reported as a limit; the forecaster's own chance of this, stated with the estimate: 85%; the middle value sits exactly at the limit.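

Neither step to compound 4, from compound 3 or from compound 2, can be read, because all values shown are limits: the limit of > 30000 nM in this assay, at which 4 of the 4 values shown sit.

The compounds shown leave open whether any terminal amine group on the shared core gives a measurable value on this read-out.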